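A few compounds are considered here, and "the series" means these few. Any claim that something is new, unique, unknown or untested is made for them only; others in the source may bear on it.

Among the measured compounds shown here, in a functional assay on HeLa cells (Homo sapiens) for antiproliferative activity, with a stated time of 48 h (a higher number here means a weaker inhibitor, a lower number a stronger inhibitor), three compounds have numbers so far. Compound 1 `C=C(Br)C(=O)Nc1ccc(/C=C/C(=O)c2ccccc2)cc1` gives 3900 nM, and compound 2 `C=C(Br)C(=O)Nc1ccc(/C=C/C(=O)c2ccc(Cl)cc2)cc1` gives 1600 nM. Compound 3 `Nc1ccc(/C=C/C(=O)c2ccccc2)cc1`, which has hydrogen in place of the (1-bromoethenyl)carbonyl group on its nitrogen, gives 36000 nM. This is the highest of the three numbers, which makes compound 3 the weakest inhibitor of the set. Losing that group is a 9.2-fold higher number from compound 1 to compound 3 (0.97 log units; beyond the scatter).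

Compound 4 `Nc1ccc(/C=C/C(=O)c2ccc(Br)cc2)cc1` differs from compound 3 in one place: bromo in place of hydrogen on an aromatic carbon. In words, this is bromo in place of hydrogen on an aromatic carbon, para to a large group.

The closest guide is the swap of hydrogen for chloro on an aromatic carbon, which is a 2.4-fold lower number from compound 1 to compound 2 (0.39 log units; beyond the scatter). For the measured compounds named here, this is only one modest step. It was measured with chloro rather than bromo, and with the (1-bromoethenyl)carbonyl group still on the nitrogen, so it carries over only loosely. Going by the values given here, no measured pair shows what bromo does on this ring.

A similar modest fall in the number is therefore expected in this assay, although a change within the scatter would be no surprise. The expected change is a 2.4-fold lower number from compound 3 to compound 4 (0.38 log units; beyond the scatter). Compound 4 is estimated at 15000 nM, with an expected range from 6000 nM to 36000 nM.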

Compound 4, half-maximal inhibitory concentration: 49000 nM
Beside the measured number, compound 4's estimate is 3.3-fold (0.51 log units) below it, outside the stated range (above it).
By their numbers in this assay, from the lowest: compound 2; then compound 1; then compounds 3 and 4 (each within the scatter of the next).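

In this assay, bromo on an aromatic carbon, para to a large group, gives a 1.4-fold higher number from compound 3 to compound 4 (0.13 log units; within the scatter), so with only hydrogens on the nitrogen this swap leaves no change that can be told from the scatter. Among the compounds shown here, this is the first view of a halogen at this position without the (1-bromoethenyl)carbonyl group, and it does not repeat the earlier chloro step, a 2.4-fold lower number from compound 1 to compound 2 (0.39 log units; beyond the scatter), although those two steps differ both in the halogen and in what sits on the nitrogen, so neither difference can be singled out as the one that matters. Nothing measured here offers an explanation for this result.

Still open, from the compounds shown here alone, is whether chloro would also leave compound 3 within the scatter, and whether bromo on compound 1 would repeat the step seen with chloro, which would show whether the halogen or the group on the nitrogen sets the outcome. Also open, going by these compounds, is whether a different group at this position, such as a methoxy group or a carboxylic acid, would move the number beyond the scatter.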